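Phthalimide-triazole thioethers at the cytotoxicity limit

The source may report more compounds than this note shows. Statements on the series, on what has been measured and on what is new or still open speak of the compounds shown alone.

Three compounds share one core, a phthalimide-bearing triazole carrying a thioether chain, and differ only in the alkyl group on the triazole: compound 1 `Cc1nnc(SCC(=O)c2ccc(Cl)cc2)n1N1C(=O)c2ccccc2C1=O`, compound 2 `CCc1nnc(SCC(=O)c2ccc(Cl)cc2)n1N1C(=O)c2ccccc2C1=O` and compound 3 `CCCc1nnc(SCC(=O)c2ccc(Cl)cc2)n1N1C(=O)c2ccccc2C1=O`. In a functional assay on HepG2 cells (Homo sapiens) for cytotoxicity, read by MTT assay, with a stated time of 48 h (on this read-out higher numbers stand for weaker inhibition and lower numbers for stronger inhibition), compound 1 gives > 200000 nM, which is a limit of the assay and not a number. In this assay compound 2 gives > 200000 nM, again a limit. In this assay compound 3 gives > 200000 nM, also a limit. The steps a step that the two limits leave unreadable from compound 1 to compound 2, a step that the two limits leave unreadable from compound 1 to compound 3 and a step that the two limits leave unreadable from compound 2 to compound 3 therefore cannot be read, and all three values sit together (the limit of > 200000 nM in this assay, at which 3 of the 3 values shown sit).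

Compound 4 `CCCc1nnc(SCc2ccccc2Cl)n1N1C(=O)c2ccccc2C1=O` departs from compound 3 at the thioether end: 2-chlorophenyl in place of (4-chlorophenyl)carbonyl on a saturated chain carbon bound to a sulfur. Going by the values given here, no measured step touches that part of the molecule, so none of them bears on this change; the only guide is that every compound so far has stayed at the limit. Compound 4 is therefore expected to show a step of a number no higher from compound 3 to compound 4 (the limit leaves the size open), meaning none beyond the scatter. For compound 4 the estimated value in this assay is 200000 nM, with a range from 100000 nM to 400000 nM.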

Compound 4, half-maximal inhibitory concentration: > 200000 nM
Compound 4 ended at the assay's limit; the forecaster's own chance of this, stated with the estimate: 85%; the middle value sits exactly at the limit.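

In this assay compound 4 gives > 200000 nM, which is a limit and not a number, so the change from compound 3 to compound 4 cannot be read as a step. The compounds shown leave open how compounds 1 to 4 rank against one another and which structural change would give a readable value: the limit of > 200000 nM in this assay, at which 4 of the 4 values shown sit.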